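Resolving One Stereocentre in the Amide Side Chain

This account rests on a few compounds, and the source may have more. Where it says the series, first, only, none or still open, it means among the compounds named here.

For the measured compounds named here, compound 1 `CC(C)C[C@H](N)c1cc(C(F)(F)F)ccc1N1CCN(C(=O)C(C)Cc2ccc(Cl)c(Cl)c2)CC1` and compound 2 `CC(C)C[C@H](N)c1cc(C(F)(F)F)ccc1N1CCN(C(=O)C(C)Cc2ccc(Cl)cc2)CC1` share the same core and differ in more than one place, so no single step between them can be read. In an assay on HEK293 cells for displacement of a labelled ligand from Melanocortin receptor 4 (Homo sapiens) (a higher number here means a weaker inhibitor, a lower number a stronger inhibitor), compound 1 gives 120 nM; 1600 nM (2 entries), and the several entries of compound 1 in this assay, 120 nM; 1600 nM (2 entries) show that its repeats sit far apart from one another. In this assay, going by the values given here, compound 2 gives 47 nM, the only single number in the set; a further entry for compound 2 gave no single number. Only these two values stand side by side, and nothing more is claimed about them.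

Compound 3 `CC(C)C[C@H](N)c1cc(C(F)(F)F)ccc1N1CCN(C(=O)[C@H](C)Cc2ccc(Cl)cc2)CC1` is compound 2 with one change: the two compounds have the same atoms and bonds; at least one stereo element is drawn with a configuration in one of them and without one in the other: 1 of 2 stereo elements differ; a stereocentre at a saturated chain carbon is drawn without a configuration in compound 2 and R in compound 3. Compound 3 is therefore one of the two forms that together make up compound 2, and its value may sit close to that of compound 2 or fall well away from it on the weaker side. Compound 3 is expected to give about 40 nM, between 12 nM and 250 nM. The step of a 1.2-fold lower number from compound 2 to compound 3 (0.07 log units; within the scatter) is expected to stay within the scatter, with the range kept wide toward weaker binding.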

Compound 3, inhibition constant: 31 nM
Estimate against measurement, compound 3: 1.3-fold (0.11 log units) above, within the range that was stated.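

In this assay, fixing the saturated chain carbon as R gives a 1.5-fold lower number from compound 2 to compound 3 (0.18 log units; within the scatter), so the two compounds cannot be told apart by their values. For the compounds shown here, this is the first comparison in the set that can be read as a single step, and it shows that a compound carrying the R configuration at this carbon binds at the same level as the compound drawn without a configuration there. The step bears on the R form only, and no value for the other form can be derived from it, since the comparison rests on a drawing with and a drawing without a configuration at this place: the fact that one of compounds 2 and 3 is drawn with a defined configuration and the other without, at the place where they differ

On these data alone, what the S form at this chain carbon gives, and whether an ethyl group on that carbon would hold the same level, remains open. Also open is whether the R form of compound 1 would fall in line with compound 3, and compound 1 offers no firm reference for that question: the several entries of compound 1 in this assay, 120 nM; 1600 nM (2 entries)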